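Aryloxy for methoxy on the compound 1 core

The source may report more compounds than this note shows. Statements on the series, on what has been measured and on what is new or still open speak of the compounds shown alone.

Measured compounds:
- compound 1 `COc1ccc(-c2ccn(CCC(C)C)c(=O)c2C#N)cc1`: 1150 nM
- compound 2 `COc1ccc(-c2ccn(CCC(C)C)c(=O)c2C#N)cc1Cl`: 363 nM

In a functional assay on CHO cells for positive allosteric modulation of metabotropic glutamate receptor 2 (Homo sapiens), read by scintillation counting and GTPgammaS binding, with a stated time of 30 min (on this read-out higher numbers stand for an effect only at larger amounts of compound and lower numbers for an effect already at smaller amounts), compound 1 gives 1150 nM, the highest of the two numbers; its nearest neighbour is compound 2, reached by a 3.2-fold lower number from compound 1 to compound 2 (0.50 log units; beyond the scatter), a chloro in place of hydrogen on an aromatic carbon.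

Compound 3 `Cc1ccc(Oc2ccc(-c3ccn(CCC(C)C)c(=O)c3C#N)cc2)c(C)n1` is not yet measured. It differs from compound 1 in one place: 2,6-dimethylpyridin-3-yl in place of methyl on an oxygen on an aromatic ring. The same difference, cut one bond further out, reads methoxy to (2,6-dimethylpyridin-3-yl)oxy.

Within the data shown here, no measured step touches this oxygen. Among the measured compounds shown here, the only step available, from compound 1 to compound 2, concerns a different part of the shared core and was modest in size, so it gives no direct read on an aryloxy in place of methoxy. What is known is that compound 1 has room to move in either direction. The expectation for compound 3 is therefore held wide, with a slight lean toward a lower number, that is a 1.9-fold lower number from compound 1 to compound 3 (0.28 log units; within the scatter). On that basis compound 3 is estimated at 600 nM, expected to fall between 120 nM and 3000 nM in this assay.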

Compound 3, half-maximal effective concentration: 100 nM
The estimate for compound 3 lay 6.0-fold (0.78 log units) above the measured number, and the stated range ends above it.
By their numbers in this assay, from the lowest: compound 3; then compound 2; then compound 1.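

In this assay, the oxygen on an aromatic ring in the shared core accepts much more than a methyl: replacing methoxy with (2,6-dimethylpyridin-3-yl)oxy gives a 12-fold lower number from compound 1 to compound 3 (1.06 log units; beyond the scatter), a large step. The earlier compounds shown here showed only a modest change elsewhere on the core, a 3.2-fold lower number from compound 1 to compound 2 (0.50 log units; beyond the scatter), and gave no information about this oxygen. The new step shows that this position can carry a substituted six-membered aromatic ring with a gain rather than a loss, and that this single change moves the number further than the chloro did. Nothing available accounts for the size of this step.

Among these compounds, with only one aryl group at this oxygen, it remains open whether the gain comes from the aromatic ring itself, its ring nitrogen or its two methyl groups; a plain phenyl and an unsubstituted pyridin-3-yl on the same oxygen would begin to separate these. Going by these compounds, it is also open whether a saturated ring such as cyclohexyl would serve here, and whether the chloro step carries over to the aryloxy compounds.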